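Aminothiophene piperazines at the adenosine A3 receptor

This account rests on a few compounds, and the source may have more. Where it says the series, first, only, none or still open, it means among the compounds named here.

Measured compounds:
compound 1 `COc1ccc(N2CCN(Cc3csc(N)c3C(=O)c3ccc(Cl)cc3)CC2)cc1`, 0%
compound 2 `Nc1scc(CN2CCN(c3ccncc3)CC2)c1C(=O)c1ccc(Cl)cc1`, 2%

Two compounds share a core and differ only in the group on the ring nitrogen of the piperazine. In an assay on CHO cells for displacement of a labelled ligand from adenosine receptor A3 (Homo sapiens), read by scintillation counting, with a stated time of 120 min, tested at 10 uM (a lower number here means less inhibition, a higher number more inhibition at the concentration tested (going by the name of the read-out)), compound 1 gives 0%, and in this assay compound 2 gives 2%. Within the data shown here, the one measured step, a number 2 percentage points higher from compound 1 to compound 2 (within the scatter), shows that swapping the aryl group on that nitrogen left the read-out essentially unchanged; the two values sit within the scatter of each other, both near the bottom of the scale.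

Compound 3 `Nc1scc(CN2CCN(c3ccc(F)cc3F)CC2)c1C(=O)c1ccc(Cl)cc1` is not yet measured. Its change from compound 2 is 2,4-difluorophenyl in place of pyridin-4-yl on an amine nitrogen in a ring. Among the measured compounds shown here, the step from compound 1 to compound 2, which also exchanged the group on the same ring nitrogen, was within the scatter, and that is the only step bearing on this change. The step of a number 1 percentage points higher from compound 2 to compound 3 (within the scatter) is therefore expected to be small, with no direction beyond the scatter. Compound 3 is accordingly estimated at 3%, with a range from -8% to 15%.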

Compound 3, a percentage reported as inhibition, at one concentration (the size of the read-out at that concentration, not a potency): 0%
Estimate against measurement, compound 3: 3 percentage points above, within the range that was stated.
By their numbers in this assay, from the lowest: compounds 1, 3 and 2 (each within the scatter of the next).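

In this assay, placing 2,4-difluorophenyl on the amine nitrogen in the ring gives a number 2 percentage points lower from compound 2 to compound 3 (within the scatter) and no change at the digits printed from compound 1 to compound 3 (within the scatter), so three different aromatic groups at this position have now been compared. Among these compounds, the change from pyridin-4-yl also removes the ring hetero atom and the hydrogen-bond acceptor from this group and brings in two fluorine atoms, yet the read-out stays within the scatter, which extends what the single earlier step showed to a ring of carbon only that carries fluorine. All three compounds remain close to the bottom of the scale, and no information is available that could explain this result.

These compounds leave open whether any group on this nitrogen can move the read-out beyond the scatter, for example a benzyl group, an acetyl group or a short alkyl chain in place of the aromatic ring directly attached. They also leave open whether the shared core can give clear inhibition with another group in place of the 4-chlorophenyl on the carbonyl, such as an unsubstituted phenyl or a cyclohexyl ring.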